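Side-chain swap on the shared core: compound 1 to compound 4

The compounds below may be only part of what the source reports. "The series", "measured", "known", "first", "only" and "open" are said of these compounds alone.

Measured so far:
compound 1 `O=C(NCCNc1nccc(-c2c(-c3cccc(F)c3)nc3sccn23)n1)c1c(F)cccc1F`: 2700 nM
compound 2 `COc1ccc(S(=O)(=O)NCCCNc2nccc(-c3c(-c4cccc(F)c4)nc4sccn34)n2)cc1`: 5510 nM
compound 3 `O=C(NCCCNc1nccc(-c2c(-c3cccc(F)c3)nc3sccn23)n1)c1ccc(Cl)cc1`: 13700 nM

In a functional assay on A-375 cells (Homo sapiens) for cytotoxicity, read by MTT assay (a higher number here means a weaker inhibitor, a lower number a stronger inhibitor), compound 1 gives the lowest of the three numbers; compound 2 sits nearest to it and compound 3 furthest, both beyond the scatter. The unmeasured compound 4 `Cc1ccc(S(=O)(=O)NCCCNc2nccc(-c3c(-c4cccc(F)c4)nc4sccn34)n2)cc1` differs from compound 1 as follows: (((4-methylphenyl)sulfonyl)amino)methyl in place of ((2,6-difluorophenyl)carbonyl)amino on a saturated chain carbon, two bonds along the chain from a nitrogen on an aromatic ring.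

Among the measured compounds shown here, two measured steps bear on this change. The step of a 5.1-fold higher number from compound 1 to compound 3 (0.71 log units; beyond the scatter) covers the same lengthening of the chain together with a carbonyl-to-carbonyl exchange of the aryl group. The step of a 2.5-fold higher number from compound 2 to compound 3 (0.40 log units; beyond the scatter) shows that, on the three-carbon chain, the sulfonyl compound 2 gives the lower number and the carbonyl compound 3 the higher one. Taken together, the chain lengthening of compound 4 points to a higher number than compound 1, while the sulfonyl group points back toward the value of compound 2, the nearest measured analogue. For the measured compounds named here, no step for methyl against methoxy on that aryl ring is available.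

The expected outcome in this assay for compound 4 is therefore a modest step upward, a 1.9-fold higher number from compound 1 to compound 4 (0.27 log units; within the scatter), landing close to compound 2. The estimate for compound 4 is 5000 nM, with a range of 2000 nM to 13000 nM.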

Compound 4, half-maximal inhibitory concentration: 8380 nM
Beside the measured number, compound 4's estimate is 1.7-fold (0.22 log units) below it; low and high end bracket the measured number.
By their numbers in this assay, from the lowest: compound 1; then compounds 2, 4 and 3 (each within the scatter of the next, the first and the last beyond it).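

In this assay, the exchange of ((2,6-difluorophenyl)carbonyl)amino for (((4-methylphenyl)sulfonyl)amino)methyl at this saturated chain carbon (a 3.1-fold higher number from compound 1 to compound 4 (0.49 log units; beyond the scatter)) is beyond the scatter, so a second sulfonyl example now separates from compound 1 along with the carbonyl compound 3. On the amine nitrogen, the exchange of (4-chlorophenyl)carbonyl for (4-methylphenyl)sulfonyl (a 1.6-fold lower number from compound 3 to compound 4 (0.21 log units; within the scatter)) lies within the scatter, whereas the earlier comparison with the (4-methoxyphenyl)sulfonyl group (a 2.5-fold higher number from compound 2 to compound 3 (0.40 log units; beyond the scatter)) lay beyond it, so a sulfonyl group alone does not give a separation from compound 3. Methyl in place of methoxy on the aromatic carbon (a 1.5-fold higher number from compound 2 to compound 4 (0.18 log units; within the scatter)) also lies within the scatter, and this assay does not resolve the two sulfonamides.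

The compounds shown leave open how much of the step from compound 1 belongs to the extra methylene of the chain and how much to the aryl group and its linking function, and how an amine or a carboxylic acid on that aryl ring would read. No measurement accompanies these numbers that could account for any of the steps.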